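Replacing Bromo with Methylpiperazinyl on the Sulfonamide Arene

The source may report more compounds than this note shows. Statements on the series, on what has been measured and on what is new or still open speak of the compounds shown alone.

Compound 1, `COc1ccc(S(=O)(=O)NCCN2CCC(CCC(=O)c3cc(Cl)c(N)cc3OC)CC2)cc1Br`: 72%
Compound 2, `COc1cc(N)c(Cl)cc1C(=O)CCC1CCN(CCNS(=O)(=O)c2ccc(N)c(Br)c2)CC1`: 85%

In an assay on HEK293 cells for displacement of a labelled ligand from 5-hydroxytryptamine receptor 6 (Homo sapiens), with a stated time of 60 min, tested at 1 uM, in the presence of a further agent that is not named here (on this read-out higher numbers stand for a stronger effect at the one concentration tested and lower numbers for a weaker effect), compound 1 gives 72%, the lower of the two measured numbers, while compound 2 gives 85%. For the measured compounds named here, the single measured step, a number 13 percentage points higher from compound 1 to compound 2 (beyond the scatter), is modest yet beyond the scatter. Compound 3, `COc1cc(N)c(Cl)cc1C(=O)CCC1CCN(CCNS(=O)(=O)c2ccc(OC)c(N3CCN(C)CC3)c2)CC1`, differs from compound 1 by 4-methylpiperazin-1-yl in place of bromo on an aromatic carbon. Going by the values given here, this exchange touches another group than the measured step, so no measured step bears on it, and no step beyond the scatter is expected in either direction. Compound 3 is therefore expected to give about 72%, estimated between 50% and 90%. The estimated step is no change at the digits printed from compound 1 to compound 3 (within the scatter).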

Compound 3, a percentage reported as inhibition, at one concentration (the size of the read-out at that concentration, not a potency): 43%
Beside the measured number, compound 3's estimate is 29 percentage points above it, outside the stated range (below it).
By their numbers in this assay, from the lowest: compound 3; then compound 1; then compound 2.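

Exchanging bromo for 4-methylpiperazin-1-yl on the aromatic carbon ortho to a methoxy group is not neutral in this assay, as it brings a number 29 percentage points lower from compound 1 to compound 3 (beyond the scatter). So the result at this position depends on the group placed there, which the earlier amino-for-methoxy step could not show. Nothing measured here explains the loss.

The compounds shown leave open whether the piperazine ring itself or its terminal methyl goes with this step. Neither an unsubstituted piperazine, a morpholine ring nor a dimethylamino group appears at this position among them.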